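The source may hold more compounds than are shown below. What is called first, only, known or untested is meant among the compounds shown, and "the series" means these compounds.

Values in a functional assay on DU-145 cells (Homo sapiens) for inhibition, read by trypan blue exclusion, with a stated time of 72 h; a lower number here means a stronger inhibitor, a higher number a weaker inhibitor:
- Compound 1 `Cn1c(=O)c(S(=O)(=O)c2ccc(F)cc2)cc2cnc(Nc3ccc4occc4c3)nc21`: 5000 nM
- Compound 2 `Cn1c(=O)c(S(=O)(=O)c2ccc(F)cc2)cc2cnc(Nc3ccc4[nH]ccc4c3)nc21`: 300 nM
- Compound 3 `Cn1c(=O)c(S(=O)(=O)c2ccc(F)cc2)cc2cnc(Nc3ccc4[nH]ncc4c3)nc21`: 5000 nM

Compound 2 has the lowest number of the three and is the strongest inhibitor here. Compound 4 `Cn1c(=O)c(S(=O)(=O)c2ccc([N+](=O)[O-])cc2F)cc2cnc(Nc3ccc4[nH]ccc4c3)nc21` differs from it only on the sulfonyl sulfur, with 2-fluoro-4-nitrophenyl in place of 4-fluorophenyl on a sulfonyl sulfur.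

The measured steps all change the group on a nitrogen instead. There is a 17-fold lower number from compound 1 to compound 2 (1.22 log units; beyond the scatter) and a 17-fold higher number from compound 2 to compound 3 (1.22 log units; beyond the scatter), both large, and no change at the digits printed from compound 1 to compound 3 (within the scatter). Within the data shown here, no measured compound varies the sulfonyl group, so these steps show only that a single swap can move this number widely, not which way this one will go.

With compound 2 already lowest at 300 nM, a moderate rise is the cautious expectation. The expected step is a 2.0-fold higher number from compound 2 to compound 4 (0.30 log units; within the scatter). Compound 4 is estimated at 600 nM, with an expected range of 100 nM to 3000 nM.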

Compound 4, half-maximal inhibitory concentration: 400 nM
Compound 4: middle estimate off by 1.5-fold (0.18 log units), on the high side; low and high end bracket the measured number.
By their numbers in this assay, from the lowest: compounds 2 and 4 (each within the scatter of the next); then compounds 1 and 3 (each within the scatter of the next).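

In this assay, among these compounds, the change on the sulfonyl sulfur gives a 1.3-fold higher number from compound 2 to compound 4 (0.12 log units; within the scatter), so this is the first view of this position, and the larger 2-fluoro-4-nitrophenyl group is tolerated here. Unlike the swaps on the nitrogen, which could move the number widely, this change leaves compound 4 level with compound 2 despite its added nitro group and hydrogen-bond acceptors. No measurement shown here explains this result.

Still open, as far as these compounds go, is how the nitro group and the fluorine each contribute on their own. Also open, from the compounds shown here alone, is whether an amine or a carboxylic acid on this ring would keep the number as low.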